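This account rests on a few compounds, and the source may have more. Where it says the series, first, only, none or still open, it means among the compounds named here.

Going by the values given here, compound 1, `Cc1ccc(NC(=O)c2cccc(/C=C3\CC(=O)N(c4ccccc4)C3=O)c2)cc1C`, is one of three compounds tested so far in an ADME assay on NCM460 cells (Homo sapiens) for cytotoxicity, read by MTT assay, with a stated time of 72 h (on this read-out lower numbers stand for stronger inhibition and higher numbers for weaker inhibition), and for it the assay returns only a limit, > 100000 nM. The same holds for compound 2, `CCCCCN1C(=O)C/C(=C\c2cccc(C(=O)Nc3cccc(CC)c3)c2)C1=O`, which gives a limit of > 100000 nM in this assay. Compound 3, `CCCCCN1C(=O)C/C(=C\c2cccc(C(=O)Nc3cccc(F)c3)c2)C1=O`, likewise gives a limit, > 100000 nM, in this assay. The one single-point step among these, fluoro in place of ethyl on an aromatic carbon, reads as a step that the two limits leave unreadable from compound 2 to compound 3, so its size cannot be told. The whole picture therefore rests on (the limit of > 100000 nM in this assay, at which 3 of the 3 values shown sit), with no finite number anywhere.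

Compound 4, `CCOc1ccc(NC(=O)c2cccc(/C=C3\CC(=O)N(c4ccccc4)C3=O)c2)cc1`, differs from compound 1 by 4-ethoxyphenyl in place of 3,4-dimethylphenyl on an amide-type nitrogen. Among the compounds with values here, no measured step touches this kind of exchange, and every value so far is a limit, so there is nothing to point to a shift beyond the scatter in either direction. Compound 4 is expected to sit near the limit as well, with an estimated step of a number no higher from compound 1 to compound 4 (the limit leaves the size open). The estimate for compound 4 in this assay is 100000 nM, with a range from 40000 nM to 300000 nM.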

Compound 4, half-maximal inhibitory concentration: > 100000 nM
Compound 4 gave a limit, no number (the forecaster's own chance of this, stated with the estimate: 85%); the middle value lies on the limit itself.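

Compound 1 and compound 4 both return only limits in this assay, so the step of 4-ethoxyphenyl in place of 3,4-dimethylphenyl cannot be read. The compounds shown leave open how any of these structures would compare on a finite number, as all rest on one limit: the limit of > 100000 nM in this assay, at which 4 of the 4 values shown sit.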